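The source may hold more compounds than are shown below. What is called first, only, known or untested is meant among the compounds shown, and "the series" means these compounds.

Measured in a functional assay on CCRF-CEM cells (Homo sapiens), read by MTT assay, with a stated time of 72 h; on this read-out higher numbers stand for weaker inhibition and lower numbers for stronger inhibition:
Compound 1 `CNc1ncnc2c1c(-c1ccsc1)cn2[C@@H]1O[C@H](CO)[C@@H](O)[C@H]1O`: > 20000 nM (a limit)
Compound 2 `CN(C)c1ncnc2c1c(-c1ccoc1)cn2[C@@H]1O[C@H](CO)[C@@H](O)[C@H]1O`: 13300 nM

The reading for compound 1 is a limit of the assay, not a number. For the measured compounds named here, compound 2, at 13300 nM, therefore provides the only numerical value so far. Compound 3 `CN(C)c1ncnc2c1c(-c1ccsc1)cn2[C@@H]1O[C@H](CO)[C@@H](O)[C@H]1O` has thiophen-3-yl in place of furan-3-yl on an aromatic carbon. Going by the values given here, no measured pair isolates this exchange, so no step beyond the usual scatter is expected in this assay, and neither direction is favoured. The expected change is a 1.1-fold lower number from compound 2 to compound 3 (0.04 log units; within the scatter). For compound 3 the estimated value is 12000 nM, with an expected range of 5000 nM to 30000 nM.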

Compound 3, half-maximal inhibitory concentration: 3480 nM
For compound 3 the middle estimate is 3.4-fold (0.54 log units) above the measured one, and the stated range ends above it.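

In this assay the exchange of furan-3-yl for thiophen-3-yl on the aromatic carbon gives a 3.8-fold lower number from compound 2 to compound 3 (0.58 log units; beyond the scatter) and so shows that this position responds to oxygen giving way to sulfur in a ring of the same size. With thiophen-3-yl held, methyl in place of hydrogen on the nitrogen gives an at least 5.7-fold lower number from compound 1 to compound 3 (0.75 log units; beyond the scatter) and so shows that this nitrogen matters too. Compound 1 stands at a limit of the assay, which makes that step only a bound: the limit of > 20000 nM in this assay, at which 1 of the 3 values shown sits.

From the compounds shown here alone, it remains open whether phenyl or pyridinyl would be tolerated on this aromatic carbon. Also open, going by these compounds, is how an ethyl group or a longer chain on the nitrogen would read.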